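This account rests on a few compounds, and the source may have more. Where it says the series, first, only, none or still open, it means among the compounds named here.

Compounds measured in an ADME assay on HEK-293T cells (Homo sapiens) for cytotoxicity, read by resazurin assay, with a stated time of 16 h; on this read-out lower numbers stand for stronger inhibition and higher numbers for weaker inhibition:
compound 1 `OC[C@H]1O[C@@H](n2cnc3c(NC4CCCC4)nc(NC4CCCC4)nc32)[C@H](O)[C@@H]1O` gives > 500000 nM, a limit of the assay.
compound 2 `OC[C@H]1O[C@@H](n2cnc3c(NC4CCCCC4)nc(NC4CCCC4)nc32)[C@H](O)[C@@H]1O` gives > 500000 nM, a limit of the assay.

Compound 1 thus stands only at a limit in this assay, and compound 2 sits at the same limit. The step that the two limits leave unreadable from compound 1 to compound 2 therefore cannot be read, and the limit of > 500000 nM in this assay, at which 2 of the 2 values shown sit, is all the evidence there is. The unmeasured compound 3 `OC[C@H]1O[C@@H](n2cnc3c(NC4CCCC4)nc(NC4CCCCC4)nc32)[C@H](O)[C@@H]1O` differs from compound 1 by cyclohexyl in place of cyclopentyl on a nitrogen on an aromatic ring. No readable step bears on this change, so no shift beyond the scatter is expected in this assay and compound 3 is expected to remain at the limit. Compound 3 is estimated at 500000 nM, between 200000 nM and 2000000 nM, a step of a number no higher from compound 1 to compound 3 (the limit leaves the size open).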

Compound 3, half-maximal inhibitory concentration: 228000 nM
For compound 3 the middle estimate is 2.2-fold (0.34 log units) above the measured one, within the range that was stated.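

In this assay, cyclohexyl in place of cyclopentyl on a nitrogen on an aromatic ring now gives the first readable step, an at least 2.1-fold lower number from compound 1 to compound 3 (0.34 log units; beyond the scatter). For the compounds shown here, this change can therefore bring the read-out off the limit at this nitrogen, which the earlier compounds could not show. Compound 2, with cyclohexyl on the other nitrogen, gives > 500000 nM, a limit.

From the compounds shown here alone, whether a phenyl ring or a longer chain on this nitrogen would lower the number further stays open. The size of the step also stays open, and most of the picture still rests on a limit: the limit of > 500000 nM in this assay, at which 2 of the 3 values shown sit.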